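A few compounds are considered here, and "the series" means these few. Any claim that something is new, unique, unknown or untested is made for them only; others in the source may bear on it.

Compound 1 `COc1ccc2cc(-c3ccccc3)c(O)nc2c1`: 10000 nM
Compound 2 `COc1cc(OC)c2cc(-c3ccccc3)c(O)nc2c1`: 10000 nM
Compound 3 `COc1ccc(-c2cc3cccc(OC)c3nc2O)cc1`: 10000 nM

In a functional assay on U-373MG ATCC cells for cytotoxicity against U373 MG (Homo sapiens), read by colorimetric assay and MTT assay (on this read-out lower numbers stand for stronger inhibition and higher numbers for weaker inhibition), compound 2 gives 10000 nM, level with compound 1 at 10000 nM and with compound 3 at 10000 nM. The next compound, compound 4 `COc1cc(OC)c2cc(-c3ccc(OCc4ccccc4)cc3)c(O)nc2c1`, differs from compound 2 by one change: benzyloxy in place of hydrogen on an aromatic carbon. This is benzyloxy in place of hydrogen on an aromatic carbon, para to a large group. Within the data shown here, the one measured step that bears on it is no change at the digits printed from compound 1 to compound 2 (within the scatter), also a replacement of hydrogen on an aromatic carbon, and it stays within the scatter. Compound 3, with a methoxy on the aromatic carbon that changes here, reads 10000 nM. Among the measured compounds shown here, no measured compound carries a benzyloxy, so the data give only weak guidance for a group of this size. What is expected is a 1.4-fold lower number from compound 2 to compound 4 (0.15 log units; within the scatter), no shift beyond the scatter, with any movement more likely toward stronger inhibition. For compound 4 the estimated value is 7000 nM, with an expected range of 2500 nM to 10000 nM.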

Compound 4, half-maximal inhibitory concentration: 10000 nM
For compound 4 the middle estimate is 1.4-fold (0.15 log units) below the measured one; the measured number falls inside the stated range.
By their numbers in this assay, from the lowest: compounds 1, 2, 3 and 4 (each within the scatter of the next).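

In this assay, placing benzyloxy in place of hydrogen on an aromatic carbon, para to a large group, gives no change at the digits printed from compound 2 to compound 4 (within the scatter). Among these compounds, the only earlier step was a methoxy in place of hydrogen at another place, so this is the first step read at this position, and it shows that a group of 8 heavy atoms carrying its own six-membered aromatic ring can enter here without a shift beyond the scatter. No measurement on hand accounts for this reading.

All four compounds print the same number, so none of them shows which structural change could move it in this assay. On these data alone, whether an amine or a carboxylic acid on this aromatic carbon would shift the number remains open, and the same holds for a longer chain in place of the benzyloxy.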